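A few compounds are considered here, and "the series" means these few. Any claim that something is new, unique, unknown or untested is made for them only; others in the source may bear on it.

The measured compounds and their values:

compound 1 `COC(=O)CCNC(=O)[C@@H]1O[P@@](=O)(OCOC(=O)c2cc(C(C)(C)C)n[nH]2)OCC1(C)C`: > 1 h
compound 2 `COC(=O)CCNC(=O)[C@@H]1OP(=O)(Oc2ccc(F)cc2)OCC1(C)C`: > 1 h
compound 3 `COC(=O)CCNC(=O)[C@@H]1O[P@](=O)(OCOC(=O)c2scnc2C(C)(C)C)OCC1(C)C`: 0.44 h

In an ADME assay on blood (Homo sapiens) for pharmacokinetics (a lower number here means that the compound disappears faster, a higher number that the compound lasts longer), compound 1 gives > 1 h, which is a limit of the assay and not a number. Compound 2 also gives only a limit, > 1 h. Among the measured compounds shown here, compound 3 is the one compound with a numeric value, 0.44 h. Compound 1 therefore stands at the limit of > 1 h in this assay, at which 2 of the 3 values shown sit, so its position relative to compound 3 is known only as being on the longer side of that limit.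

Compound 4 `COC(=O)CCNC(=O)[C@@H]1O[P@@](=O)(OCOC(=O)c2ccns2)OCC1(C)C` is not yet measured. It differs from compound 1 in one place: 1,2-thiazol-5-yl in place of 3-(tert-butyl)-1H-pyrazol-5-yl on a carbonyl carbon. For the measured compounds named here, no step between two measured compounds with a single change is available, so the size of this change has to be guessed from the spread of the three values shown, which run from the number of compound 3 to the limit reached by compound 1 and compound 2.

The expected half-life of compound 4 is 0.8 h, within 0.3 h to 2.5 h. This expectation corresponds to a step of an at least 1.2-fold lower number from compound 1 to compound 4 (0.09 log units; that floor lies within the scatter), a modest shortening that may not exceed the usual scatter.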

Compound 4, half-life: < 0.16 h
Compound 4: a limit, no number; the forecaster's own chance of this, stated with the estimate: 35%; middle value at least 5.0-fold (0.69 log units) away from the limit.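

Within this assay, placing 1,2-thiazol-5-yl instead of 3-(tert-butyl)-1H-pyrazol-5-yl on the carbonyl carbon gives an at least 6.2-fold lower number from compound 1 to compound 4 (0.79 log units; beyond the scatter), which shows that this position is not indifferent to the group it carries. Compound 4 stands at a limit of the assay and not at a number: the limit of < 0.16 h in this assay, at which 1 of the 4 values shown sits. From the compounds shown here alone, compound 1 also stands at a limit, so the change spans the measurable range and its full size stays unknown: the limit of > 1 h in this assay, at which 2 of the 4 values shown sit.

The change replaces the ring and removes the tert-butyl group in one step, so the compounds shown leave open which of the two carries the drop. Going by these compounds, it also remains open how an unsubstituted 1H-pyrazol-5-yl group or a 3-methyl-1H-pyrazol-5-yl group would stand in this assay.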